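This account rests on a few compounds, and the source may have more. Where it says the series, first, only, none or still open, it means among the compounds named here.

Measured compounds in a functional assay on HL-60 cells (Homo sapiens) for cytotoxicity, read by CCK-8 assay, with a stated time of 72 h; a higher number here means a weaker inhibitor, a lower number a stronger inhibitor:
- compound 1, `COc1ccccc1/C=c1\c(=O)[nH]/c(=C/c2cccc(Cl)c2Cl)c(=O)n1C`: 200 nM
- compound 2, `C=CCn1c(=O)/c(=C\c2ccc(Cl)c(Cl)c2)[nH]c(=O)/c1=C\c1ccccc1`: "not active" (no number reported)
- compound 3, `C=CCn1c(=O)/c(=C\c2cccc(F)c2)[nH]c(=O)/c1=C\c1ccccc1OC`: 8890 nM

Compound 1 has the lowest of the two reported numbers in this assay; compound 3 lies well beyond the scatter above it, and compound 2 has no number at all. Among the compounds with values here, nothing links these three by a single change, so no measured step can be quoted.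

Compound 4, `C=CCn1c(=O)/c(=C\c2cccc(Cl)c2Cl)[nH]c(=O)/c1=C\c1ccccc1OC`, is to be measured in this assay. Against compound 1 the change is vinyl in place of hydrogen on a saturated chain carbon bound to an aromatic nitrogen. Compound 4 shares its allyl group with compound 2 and compound 3 and its aryl groups with compound 1. The expectation for compound 4 is a step toward weaker inhibition, beyond the scatter but smaller than the gap between compound 1 and compound 3, because compound 3 with the same allyl group gives 8890 nM while compound 2 gives "not active" (no number reported). Compound 4 is therefore estimated at 800 nM, within 200 nM to 6000 nM, an expected step of a 4.0-fold higher number from compound 1 to compound 4 (0.60 log units; beyond the scatter).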

Compound 4, half-maximal inhibitory concentration: 2000 nM
Compound 4: middle estimate off by 2.5-fold (0.40 log units), on the low side, within the range that was stated.
By their numbers in this assay, from the lowest: compound 1; then compound 4; then compound 3.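

In this assay, methyl to allyl with both aryl groups held now has a measured step of its own: vinyl in place of hydrogen on a saturated chain carbon bound to an aromatic nitrogen gives a 10-fold higher number from compound 1 to compound 4 (1.00 log units; beyond the scatter) and so this place is sensitive to the change. With the allyl group held, 2,3-dichlorophenyl in place of 3-fluorophenyl on a double-bonded chain carbon bound to an aromatic carbon gives a 4.4-fold lower number from compound 3 to compound 4 (0.65 log units; beyond the scatter) and so the aryl group still shifts the number in allyl compounds. No measurement on hand accounts for either step.

Still open, on these data alone, is whether the weakening follows chain length, which an ethyl or propyl group in place of the methyl group would test, or depends on the double bond of the allyl group. Also open, as far as these compounds go, is whether the aryl step has the same size in methyl compounds.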